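The compounds below may be only part of what the source reports. "The series", "measured", "known", "first", "only" and "open" are said of these compounds alone.

Measured so far, in a functional assay on MT4 cells (Homo sapiens) for cytotoxicity, read by MTT assay; on this read-out higher numbers stand for lower toxicity in this test and lower numbers for higher toxicity in this test:
compound 1 `Cc1c(O)nc(SCc2ccc(O)cc2)nc1Cc1c(Cl)cccc1Cl`: 41000 nM
compound 2 `Cc1c(O)nc(S(=O)(=O)Cc2ccc([N+](=O)[O-])cc2)nc1Cc1c(Cl)cccc1Cl`: > 53000 nM, a limit of the assay
compound 3 `COc1ccc(CCSc2nc(Cc3c(Cl)cccc3Cl)c(C)c(=O)[nH]2)cc1`: > 57000 nM, a limit of the assay

For the measured compounds named here, compound 1 gives 41000 nM in this assay and is the only compound of the three with a plain number. For compound 2 the result > 53000 nM is a limit of the assay and not a number. For compound 3 the result > 57000 nM is likewise a limit. The two limits are recorded as the limit of > 53000 nM in this assay, at which 1 of the 3 values shown sits, and (the limit of > 57000 nM in this assay, at which 1 of the 3 values shown sits); they leave compound 2 and compound 3 unranked against compound 1 beyond what the limits themselves show.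

Compound 4 `Cc1c(O)nc(SCc2ccccc2)nc1Cc1c(Cl)cccc1Cl` differs from compound 1 by hydrogen in place of hydroxy on an aromatic carbon. Going by the values given here, no pair of measured compounds differs in a single place, so no measured step of this kind is available for comparison. The step of a 1.0-fold lower number from compound 1 to compound 4 (0.01 log units; within the scatter) is expected to stay within the usual scatter, with no clear direction. Compound 4 is therefore estimated at 40000 nM in this assay, between 18000 nM and 80000 nM.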

Compound 4, half-maximal cytotoxic concentration: > 64000 nM
Compound 4: no number, only a limit; the forecaster's own chance of this, stated with the estimate: 35%; middle value at least 1.6-fold (0.20 log units) away from the limit.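

In this assay, for the compounds shown here, the change from 4-hydroxybenzyl to benzyl gives an at least 1.5-fold higher number from compound 1 to compound 4 (0.19 log units; that floor lies within the scatter), the first reading of this position. Compound 4 gives > 64000 nM, which is a limit of the assay and not a number, so only a floor on the step is known, and that floor does not separate the two compounds. The hydroxy on the aromatic carbon is therefore not required for a result this high in this test, and hydrogen at the same place brings no lower number.

How far compound 4 lies past its limit remains unknown, so a real gain from losing the hydroxy can be neither shown nor excluded. Also open, going by these compounds, is how an amine or a carboxylic acid at this place on the otherwise unchanged benzyl would read.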